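A few compounds are considered here, and "the series" means these few. Any claim that something is new, unique, unknown or untested is made for them only; others in the source may bear on it.

Compound 1 `CCCCN(c1nc2c(CO)cccc2o1)[C@H](C)c1ccc(-c2ccccc2-c2nnn[nH]2)cc1` is examined in an ADME assay on the whole organism (Macaca fascicularis) for pharmacokinetics, read by LC-MS, using cassette dosing, at a dose of 1 mg/kg by the oral route (a higher number here means more compound in the circulation at the dose given, a lower number less compound in the circulation), where compound 1 gives 20 ng.h/mL. That is the lowest of the three numbers at hand: compound 2 `Cc1ccc(-c2nc(=O)o[nH]2)c(-c2ccc([C@@H](C)N(CC3CC3)c3nc4c(C(=O)O)cccc4o3)cc2)c1` gives 4830 ng.h/mL and compound 3 `C[C@H](c1ccc(-c2cc(F)ccc2-c2nc(=O)o[nH]2)cc1)N(CC1CC1)c1nc2c(C(=O)O)cccc2o1` gives 4410 ng.h/mL, both far beyond the scatter above compound 1. Among the measured compounds shown here, the one measured step, a 1.1-fold lower number from compound 2 to compound 3 (0.04 log units; within the scatter), concerns a different change on a different core and does not bear on the present one. Compound 4 `CCCCN(c1nc2c(C(=O)N(C)C)cccc2o1)[C@H](C)c1ccc(-c2ccccc2-c2nnn[nH]2)cc1` differs from compound 1 by dimethylcarbamoyl in place of hydroxymethyl on an aromatic carbon. For the measured compounds named here, no measured pair shows this exchange, so no step beyond the scatter is expected in this assay, only a broad uncertainty. Compound 4 is therefore estimated at 30 ng.h/mL, within 6 ng.h/mL to 150 ng.h/mL, an expected step of a 1.5-fold higher number from compound 1 to compound 4 (0.18 log units; within the scatter).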

Compound 4, area under the concentration-time curve: 104 ng.h/mL
Compound 4: middle estimate off by 3.5-fold (0.54 log units), on the low side, and the stated range covers the measured number.
By their numbers in this assay, from the lowest: compound 1; then compound 4; then compounds 3 and 2 (each within the scatter of the next).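

At this aromatic carbon of the core of compound 1, the group carried matters in this assay: dimethylcarbamoyl in place of hydroxymethyl gives a 5.2-fold higher number from compound 1 to compound 4 (0.72 log units; beyond the scatter). This is the only step shown at this position, and the earlier pair, which differs elsewhere on another core, stayed within the scatter. Left open is whether a carboxylic acid or an unsubstituted carboxamide on this aromatic carbon would change the number further, and whether the step follows the carbonyl or the two methyl groups. Nothing measured on these compounds offers a reason for the rise.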